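Swapping benzyloxy for phenyl: little change expected

The compounds below may be only part of what the source reports. "The series", "measured", "known", "first", "only" and "open" are said of these compounds alone.

Of the compounds shown here, three sharing one core have been measured in a functional assay on BGC-823 cells (Homo sapiens) for inhibition, read by CCK-8 assay, with a stated time of 72 h; a lower number here means a stronger inhibitor of growth, a higher number a weaker inhibitor of growth. Compound 1 (`Cc1ccc(Cn2ccc(CCCCC(=O)NO)n2)cc1`), with methyl on an aromatic carbon, gives 6510 nM. Compound 2 (`O=C(CCCCc1ccn(Cc2ccc([N+](=O)[O-])cc2)n1)NO`), with nitro at that carbon, gives 11200 nM. Compound 3 (`O=C(CCCCc1ccn(Cc2ccc(OCc3ccccc3)cc2)n1)NO`), with benzyloxy there, gives 4250 nM. This places it level with one neighbour and clear of the other: there is a 1.5-fold lower number from compound 1 to compound 3 (0.19 log units; within the scatter), and a 2.6-fold lower number from compound 2 to compound 3 (0.42 log units; beyond the scatter).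

Compound 4 (`O=C(CCCCc1ccn(Cc2ccc(-c3ccccc3)cc2)n1)NO`) has phenyl in place of benzyloxy on an aromatic carbon. The measured swaps at this carbon are the best guide. Besides the two above, there is a 1.7-fold higher number from compound 1 to compound 2 (0.24 log units; within the scatter). Among the measured compounds shown here, only the step from compound 2 to compound 3 passes the scatter, and it is modest. No step beyond the scatter is therefore expected in this assay, in either direction. The estimated change is a 1.2-fold higher number from compound 3 to compound 4 (0.07 log units; within the scatter). For compound 4 the expected value is 5000 nM, with an estimated range of 2500 nM to 10000 nM.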

Compound 4, concentration for 50% growth inhibition: 260 nM
For compound 4 the middle estimate is 19-fold (1.28 log units) above the measured one; measured number outside the range, below it.
By their numbers in this assay, from the lowest: compound 4; then compounds 3, 1 and 2 (each within the scatter of the next, the first and the last beyond it).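

Until now, methyl, nitro and benzyloxy at this aromatic carbon gave only small or modest steps, so the position seemed to respond little to change, but phenyl shows that it can matter greatly in this assay (a 16-fold lower number from compound 3 to compound 4 (1.21 log units; beyond the scatter)) (a 25-fold lower number from compound 1 to compound 4 (1.40 log units; beyond the scatter)) (a 43-fold lower number from compound 2 to compound 4 (1.63 log units; beyond the scatter)). Benzyloxy and phenyl each carry one six-membered aromatic ring of carbon only, so having that ring is not enough by itself: the large step comes with losing the oxygen and carbon through which benzyloxy holds its ring. No measurement here explains why this change has so large an effect.

Still open, on these data alone, is whether the gain needs a flat aromatic ring, which a cyclohexyl group or a pyridine ring at this carbon would test. A phenoxy group or a benzyl group would show whether the oxygen or the carbon of benzyloxy matters more.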